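Neopentyloxy analogue of a piperazine-linked nicotinamide series

A few compounds are considered here, and "the series" means these few. Any claim that something is new, unique, unknown or untested is made for them only; others in the source may bear on it.

Compound 1 `CN(C)C(=O)c1cccnc1NCCCN1CCN(c2ccccc2O)CC1` gives 63.1 nM in a functional assay on aorta for antagonist activity at Alpha-1D adrenergic receptor (Rattus norvegicus); a lower number here means tighter binding, a higher number weaker binding.
Compound 2 `CCOc1ccccc1N1CCN(CCCNc2ncccc2C(=O)N(C)C)CC1` gives 7.94 nM in this assay.
Compound 3 `CN(C)C(=O)c1cccnc1NCCCN1CCN(c2ccccc2OCC(F)(F)F)CC1` gives 15.9 nM in this assay.

Compound 3 holds the second highest of the three numbers. Its nearest step is a 2.0-fold higher number from compound 2 to compound 3 (0.30 log units; within the scatter), within the scatter; its furthest is a 4.0-fold lower number from compound 1 to compound 3 (0.60 log units; beyond the scatter), beyond it.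

Compound 4 `CN(C)C(=O)c1cccnc1NCCCN1CCN(c2ccccc2OCC(C)(C)C)CC1` differs from compound 3 by tert-butyl in place of trifluoromethyl on a saturated chain carbon bound to an oxygen on an aromatic ring. Within the data shown here, two measured steps bear on this position: a 7.9-fold lower number from compound 1 to compound 2 (0.90 log units; beyond the scatter) and a 4.0-fold lower number from compound 1 to compound 3 (0.60 log units; beyond the scatter) show that placing a group on this oxygen lowers the number, whereas a 2.0-fold higher number from compound 2 to compound 3 (0.30 log units; within the scatter) shows that exchanging methyl for trifluoromethyl there stays within the scatter. Among the measured compounds shown here, no measured step covers tert-butyl. The step of a 1.2-fold lower number from compound 3 to compound 4 (0.09 log units; within the scatter) is therefore expected to remain within the scatter in this assay. Compound 4 is estimated at 13 nM, with a range of 4 nM to 40 nM.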

Compound 4, dissociation constant: 50.1 nM
Compound 4: the middle estimate sits 3.9-fold (0.59 log units) below what was measured; measured number above the stated range.
By their numbers in this assay, from the lowest: compounds 2 and 3 (each within the scatter of the next); then compounds 4 and 1 (each within the scatter of the next).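

In this assay, trifluoromethyl and tert-butyl hold the same count of heavy atoms, yet exchanging them gives a step beyond the scatter (a 3.2-fold higher number from compound 3 to compound 4 (0.50 log units; beyond the scatter)), so this position separates groups of equal count. Neopentyl also keeps none of what ethyl and 2,2,2-trifluoroethyl brought on this oxygen: its step from hydrogen stays within the scatter (a 1.3-fold lower number from compound 1 to compound 4 (0.10 log units; within the scatter)), while its step from ethyl is larger (a 6.3-fold higher number from compound 2 to compound 4 (0.80 log units; beyond the scatter)).

Open is where an isopropyl group or a straight propyl chain on this oxygen would fall among these compounds. No measured evidence here gives a reason for the neopentyl result.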